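A few compounds are considered here, and "the series" means these few. Any claim that something is new, unique, unknown or untested is made for them only; others in the source may bear on it.

Values in a physicochemical assay for solubility, read by spectrophotometry, using the shake flask method, with a stated time of 2 days, at pH 6.5; a higher number here means a more soluble compound, a lower number a less soluble compound:
compound 1 `O=C(O)COc1ccc2nc(-c3cn(-c4ccc(O)cc4)nn3)ccc2c1`: 365 ug/mL
compound 2 `O=C(O)COc1ccc2nc(-c3cn(-c4ccc(O)c(F)c4)nn3)ccc2c1`: 37 ug/mL
compound 3 `O=C(O)CCCOc1ccc2nc(-c3cn(-c4ccc(O)c(F)c4)nn3)ccc2c1`: 19.2 ug/mL

Compound 3 at 19.2 ug/mL lies within the scatter of compound 2, and both sit well under compound 1 at 365 ug/mL.

Compound 4 `NCCOCCOc1ccc2nc(-c3cn(-c4ccc(O)c(F)c4)nn3)ccc2c1` has not yet been measured. The structural change is 2-aminoethoxy in place of carboxymethyl on a saturated chain carbon, two bonds along the chain from an oxygen on an aromatic ring. In words, this is 2-aminoethoxy in place of carboxymethyl on a saturated chain carbon, two bonds along the chain from an oxygen on an aromatic ring. Cut one bond further out, it reads 3-carboxypropoxy to 2-(2-aminoethoxy)ethoxy.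

Going by the values given here, no measured step replaces the carboxy end of the chain, so the evidence is indirect. The closest is the step in the same chain, a 1.9-fold lower number from compound 2 to compound 3 (0.28 log units; within the scatter), which stays within the scatter. Among the compounds with values here, the only step beyond the scatter, a 9.9-fold lower number from compound 1 to compound 2 (0.99 log units; beyond the scatter), is fluoro in place of hydrogen on an aromatic carbon, and that part is unchanged in compound 4. On this limited basis, the expected step, a 1.6-fold higher number from compound 3 to compound 4 (0.19 log units; within the scatter), is not expected to exceed the scatter, though the uncertainty in either direction is wide. In this assay the estimate for compound 4 is 30 ug/mL, with an expected range of 5 ug/mL to 150 ug/mL.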

Compound 4, solubility: 9.1 ug/mL
For compound 4 the middle estimate is 3.3-fold (0.52 log units) above the measured one, within the range that was stated.
By their numbers in this assay, from the lowest: compound 4; then compounds 3 and 2 (each within the scatter of the next); then compound 1.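

In this assay, 2-aminoethoxy in place of carboxymethyl gives a 2.1-fold lower number from compound 3 to compound 4 (0.32 log units; beyond the scatter). The change at the end of the chain therefore moves this read-out past the scatter, whereas the chain extension alone gave only a 1.9-fold lower number from compound 2 to compound 3 (0.28 log units; within the scatter). Read from the shorter chain, (2-aminoethoxy)methyl in place of carboxy gives a 4.1-fold lower number from compound 2 to compound 4 (0.61 log units; beyond the scatter), so compound 4 stands apart from both carboxy-ended compounds that share its fluoro group, by a modest margin in each case. No measurement at hand bears on why the number falls at this position.

The change alters the chain's interior and its end at once, so the step cannot be assigned to the ether oxygen or to the terminal amine alone; an all-carbon chain ending in an amine and an ether-containing chain ending in a carboxylic acid would separate the two. Also open, as far as these compounds go, is how the 2-(2-aminoethoxy)ethoxy chain behaves on the core of compound 1, with hydrogen in place of fluoro, and whether a secondary or tertiary amine at the chain end would read the same.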